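This account rests on a few compounds, and the source may have more. Where it says the series, first, only, none or still open, it means among the compounds named here.

Measured compounds:
- compound 1 `Oc1ccc(-c2cc(-c3cccc(Cl)c3)nc(-c3ccccn3)c2)cc1`: 0%
- compound 2 `Oc1ccc(-c2cc(-c3ccsc3)nc(-c3cccc(Cl)c3)c2)cc1`: "not determined" (no result reported)

Compound 1 was tested in an assay on isolated protein for inhibition of DNA topoisomerase 1 (Homo sapiens), with a stated time of 30 min, tested at 20 uM (on this read-out higher numbers stand for a stronger effect at the one concentration tested and lower numbers for a weaker effect), and in that test compound 1 gives 0%, so at the single concentration used it shows no measurable effect. Compound 2 shares the 4-hydroxyphenyl group on the core but carries a thiophen-3-yl group and a 3-chlorophenyl group on the other two positions; for compound 2 the assay gave no result, so there is no number to place it by, and nothing can be said about how it compares with compound 1.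

Compound 3 `Oc1ccc(-c2cc(-c3ccc(Cl)cc3)nc(-c3ccsc3)c2)cc1` differs from compound 2 in one place: 4-chlorophenyl in place of 3-chlorophenyl on an aromatic carbon. Both compounds hold the same atoms, joined differently, and the thiophen-3-yl and 4-hydroxyphenyl groups stay where they are.

Among the measured compounds shown here, with no step between measured compounds available and the only number in this assay being the nil result of compound 1, no change beyond the scatter is expected from this rearrangement. Compound 3 is therefore expected to give about 5%, within a range of 0% to 20%.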

Compound 3, a percentage reported as inhibition, at one concentration (the size of the read-out at that concentration, not a potency): 30.7%
For compound 3 the middle estimate is 25.7 percentage points below the measured one, outside the stated range (above it).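

No step can be read between compound 2 and compound 3: in this assay compound 2 gives "not determined" (no result reported) and so offers no number to set against compound 3. The compounds shown leave open whether 4-chlorophenyl in place of 3-chlorophenyl changes the effect at all. Nothing measured here bears on the result of compound 3.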